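This account rests on a few compounds, and the source may have more. Where it says the series, first, only, none or still open, it means among the compounds named here.

Within the data shown here, compound 2 `Cc1cc(NC(=O)Cn2nnc(-c3ccccc3)n2)n(C2CCCC2)n1` is one of two compounds measured so far, and the two maximal responses lie within the scatter of each other: in an assay on HEK293 cells for activation of Kir3.1/Kir3.2 (Homo sapiens), read by thallium flux (a higher number here means a larger maximal response, a lower number a smaller maximal response), compound 2 gives 105%, while compound 1 `Cc1cc(NC(=O)Cn2nnc(-c3ccccc3)n2)n(C(C)C)n1` gives 107%. Among the measured compounds shown here, the only measured step, a number 2 percentage points lower from compound 1 to compound 2 (within the scatter), changes the group on the aromatic nitrogen and stays within the scatter. Compound 3 `Cc1cc(NC(=O)Cn2nnc(-c3ccccc3)n2)n(C2CCS(=O)(=O)C2)n1` differs from compound 2 by 1,1-dioxothiolan-3-yl in place of cyclopentyl on an aromatic nitrogen. Since that single step bearing on this position was small, no change beyond the scatter in this assay is expected. Compound 3 is therefore estimated at 100%, in a range of 80% to 115%. This estimate means an expected step of a number 5 percentage points lower from compound 2 to compound 3 (within the scatter).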

Compound 3, largest response reached (Emax), in percent of the reference or control that the assay uses: 93%
For compound 3 the middle estimate is 7 percentage points above the measured one; low and high end bracket the measured number.
By their numbers in this assay, from the lowest: compound 3; then compounds 2 and 1 (each within the scatter of the next).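

Read in this assay, the position on the aromatic nitrogen turns out to respond to the group it carries: 1,1-dioxothiolan-3-yl gives a number 12 percentage points lower from compound 2 to compound 3 (beyond the scatter) against cyclopentyl and a number 14 percentage points lower from compound 1 to compound 3 (beyond the scatter) against isopropyl, whereas the earlier step between the two carbon-only groups stayed within the scatter. Both steps are modest, so a large maximal response survives this change. Nothing at hand explains the steps. Open, from the compounds shown here alone, is whether an amine or a carboxylic acid on this nitrogen would lower the response further or leave it unchanged.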